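The source may report more compounds than this note shows. Statements on the series, on what has been measured and on what is new or still open speak of the compounds shown alone.

Compound 1 `C/C(=C\c1cc(C2=CCCCC2)co1)C(N)=O`, compound 2 `C/C(=C\c1cc(-c2ccc(C)cc2)cs1)C(N)=O` and compound 3 `C/C(=C\c1nc(-c2ccccc2)cs1)C(N)=O` have all been tested in a functional assay on T-24 cells (Homo sapiens) for cytotoxicity, read by CCK-8 assay, with a stated time of 24 h; on this read-out higher numbers stand for weaker inhibition and lower numbers for stronger inhibition. Compound 1 reached only a limit of the assay in this assay, > 50000 nM. Compound 2 likewise reached only a limit in this assay, > 50000 nM. Compound 3 too gave only a limit in this assay, > 50000 nM. Compound 2 therefore stands where everything measured so far stands, at the limit, and no number separates it from compound 1 or compound 3 (the limit of > 50000 nM in this assay, at which 3 of the 3 values shown sit).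

Compound 4 `C=Cc1ccc(-c2csc(/C=C(\C)C(N)=O)c2)cc1` has not yet been measured. It differs from compound 2 by vinyl in place of methyl on an aromatic carbon of a six-membered aromatic ring of carbon only, para to a large group. For the measured compounds named here, no step between two measured compounds is available to size such a change. Because every value shown sits at the limit (the limit of > 50000 nM in this assay, at which 3 of the 3 values shown sit), the expected step of a number no higher from compound 2 to compound 4 (the limit leaves the size open) is none beyond the scatter. Compound 4 is accordingly estimated at 50000 nM in this assay, expected between 20000 nM and 120000 nM, and most likely again reported only as a limit.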

Compound 4, half-maximal inhibitory concentration: > 50000 nM
Compound 4: only a limit was reported; the forecaster's own chance of this, stated with the estimate: 75%; the middle value sits exactly at the limit.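

Compound 2 and compound 4 both gave only a limit, so the step of vinyl in place of methyl on an aromatic carbon cannot be read. The compounds shown leave open what, if anything, separates them in this assay, since all share one limit: the limit of > 50000 nM in this assay, at which 4 of the 4 values shown sit.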